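Swapping one ring substituent in a diacylhydrazine pair

This account rests on a few compounds, and the source may have more. Where it says the series, first, only, none or still open, it means among the compounds named here.

Measured compounds:
- compound 1, `CC(C)(C)N(NC(=O)c1ccccc1)C(=O)c1ccccc1C(F)(F)F`: 631 nM
- compound 2, `CC(C)(C)N(NC(=O)c1ccccc1F)C(=O)c1ccccc1Cl`: 51.3 nM

Both compounds share the same core and were tested in an assay on cells for agonist activity at ecdysone receptor (Bombyx mori), read by a luciferase reporter, with a stated time of 24 h; on this read-out lower numbers stand for an effect already at smaller amounts and higher numbers for an effect only at larger amounts of compound. Compound 1 gives 631 nM. Compound 2 gives 51.3 nM, the lower of the two numbers, and the gap to compound 1 lies beyond the scatter of this kind of measurement. Compound 2 therefore shows its effect at smaller amounts than compound 1. The two structures differ in more than one place, so no single change can be credited with that gap; only the two numbers themselves can be compared.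

Compound 3, `CC(C)(C)N(NC(=O)c1cccc(Cl)c1)C(=O)c1ccccc1Cl`, has not yet been measured. It differs from compound 2 by 3-chlorophenyl in place of 2-fluorophenyl on a carbonyl carbon. For the measured compounds named here, no measured pair shows what such a swap does here, so the expectation rests only on the closeness of the two structures: a step of modest size, within or near the scatter, with no direction established. On that basis, the step from compound 2 to compound 3 is expected to be a 1.3-fold lower number from compound 2 to compound 3 (0.11 log units; within the scatter) in this assay. Compound 3 is estimated at 40 nM, within a range from 10 nM to 160 nM.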

Compound 3, half-maximal effective concentration: 155 nM
The estimate for compound 3 lay 3.9-fold (0.59 log units) below the measured number, within the range that was stated.
By their numbers in this assay, from the lowest: compound 2; then compound 3; then compound 1.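

In this assay, this pair gives the first single-place comparison, and it shows that the aromatic group on a carbonyl carbon whose other neighbours are: amide-type nitrogen, can change the read-out: the swap gives a 3.0-fold higher number from compound 2 to compound 3 (0.48 log units; beyond the scatter). The two groups match in the counts computed for them, with the same number of heavy atoms, the same ring, no hydrogen-bond donors or acceptors and no net charge, so those counts do not separate them, while the assay does. Within this single pair, 2-fluorophenyl goes with the lower number, although one pair establishes no trend for the position.

No measurement available here explains why the number moved.

As far as these compounds go, the step changes the halogen from fluorine to chlorine and also changes where the halogen sits on the ring, so the share of each change remains open. Also open, from the compounds shown here alone, is how a methoxy group, an amine or a carboxylic acid on this ring would behave, and whether the same step would hold with a different group on the other side of the shared core.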